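Dropping one chloro from a purine-like pair of growth inhibitors

A few compounds are considered here, and "the series" means these few. Any claim that something is new, unique, unknown or untested is made for them only; others in the source may bear on it.

Two close relatives have been measured so far. Compound 1 `ClCc1ccccc1Cn1cnc2c(Cl)nc(Cl)nc21` and compound 2 `ClCc1ccc(Cn2cnc3nc(Cl)nc(Cl)c32)cc1` share a fused two-ring core that carries two chloro groups; they differ only in where the chloromethyl-bearing benzyl arm sits. In a functional assay on A549 cells (Homo sapiens) for cytotoxicity, read by sulforhodamine B assay, with a stated time of 48 h (a higher number here means a weaker inhibitor of growth, a lower number a stronger inhibitor of growth), compound 1 gives 2230 nM, and compound 2 gives 2130 nM. Compound 2 holds the lower of these two numbers, but the gap to compound 1 lies within the scatter, so the two cannot be told apart.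

Compound 3 `ClCc1ccc(Cn2cnc3ncnc(Cl)c32)cc1` has not been measured. It differs from compound 2 by hydrogen in place of chloro on an aromatic carbon, a position between two ring nitrogen atoms. Within the data shown here, no measured pair shows this change, so its effect is unknown. A modest weakening beyond the scatter is expected, as a 1.6-fold higher number from compound 2 to compound 3 (0.22 log units; within the scatter). Compound 3 is estimated at 3500 nM, within 1200 nM to 10000 nM.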

Compound 3, concentration for 50% growth inhibition: 1810 nM
Beside the measured number, compound 3's estimate is 1.9-fold (0.29 log units) above it; the measured number falls inside the stated range.
By their numbers in this assay, from the lowest: compounds 3, 2 and 1 (each within the scatter of the next).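

On an aromatic carbon between two ring nitrogen atoms, hydrogen in place of chloro gives a 1.2-fold lower number from compound 2 to compound 3 (0.07 log units; within the scatter) in this assay. The earlier pair varied only the place of the chloromethyl-bearing benzyl arm, whereas this step shows that the chloro at this position can go without a difference this assay can detect, so a single chloro on the core is enough for growth inhibition in this range. No supporting measurement is available to explain this result.

The compounds shown leave open whether an amine or a methoxy group at this position would give a similar number. They also leave open what happens when the remaining chloro or the chloromethyl group is replaced, for example by hydrogen or a methyl group.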